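A methyl-to-fluoro swap on compound 2

The compounds below may be only part of what the source reports. "The series", "measured", "known", "first", "only" and "open" are said of these compounds alone.

In a functional assay on MCF7 cells (Homo sapiens) for antiproliferative activity, read by MTT assay, with a stated time of 48 h (on this read-out lower numbers stand for stronger inhibition and higher numbers for weaker inhibition), compound 1 `COc1ccc(-c2nnc(NC(=O)/C=C/c3ccc(F)cc3)s2)cc1` gives 0.85 ug/mL and compound 2 `Cc1ccc(/C=C/C(=O)Nc2nnc(-c3ccccc3)s2)cc1` gives 1.23 ug/mL. These two values lie within the usual scatter of each other, so compound 2 cannot be ranked apart from compound 1. Compound 3 `O=C(/C=C/c1ccc(F)cc1)Nc1nnc(-c2ccccc2)s1` differs from compound 2 at one place, 4-methylphenyl to 4-fluorophenyl, with fluoro in place of methyl on an aromatic carbon. Compound 1, at 0.85 ug/mL, also carries 4-fluorophenyl, though it differs from compound 3 elsewhere, so no step beyond the scatter is expected in this assay. The estimated change is a 1.2-fold lower number from compound 2 to compound 3 (0.09 log units; within the scatter). The expected value for compound 3 is 1 ug/mL, with an estimated range of 0.4 ug/mL to 2.5 ug/mL.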

Compound 3, half-maximal inhibitory concentration: 1.45 ug/mL
Estimate against measurement, compound 3: 1.5-fold (0.16 log units) below; the measured number falls inside the stated range.
By their numbers in this assay, from the lowest: compounds 1, 2 and 3 (each within the scatter of the next).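

In this assay, fluoro in place of methyl on the aromatic carbon gives a 1.2-fold higher number from compound 2 to compound 3 (0.07 log units; within the scatter), so these two groups cannot be told apart at this position. Hydrogen in place of methoxy on an aromatic carbon elsewhere in the molecule gives a 1.7-fold higher number from compound 1 to compound 3 (0.23 log units; within the scatter), so that change cannot be read as a real difference either. Nothing here offers an explanation for these results. From the compounds shown here alone, it remains open whether a very different group at the fluoro position, such as an amine or a carboxylic acid, would move the number beyond the scatter.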